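The source may hold more compounds than are shown below. What is called first, only, known or untested is meant among the compounds shown, and "the series" means these compounds.

Measured so far:
compound 1 `COc1cc(C2=NN(C(C)=O)C(c3cc(Cl)cc(Cl)c3)O2)cc(OC)c1OC`, in a functional assay on PC-3 cells (Homo sapiens) for antiproliferative activity, read by MTT assay, tested at 1 uM (a lower number here means a weaker effect, a higher number a stronger effect of the compound at the concentration tested), compound 1 gives 52.7%
compound 2 `COc1cc(C(=O)N/N=C/c2ccccc2C(F)(F)F)cc(OC)c1OC`, in this assay compound 2 gives 45%

Of the two numbers, compound 1 gives the larger one, but the gap to compound 2 is within the scatter, so the two are not told apart in this assay.

Compound 3 `COc1ccc(OC)c(C2OC(c3cc(OC)c(OC)c(OC)c3)=NN2C(C)=O)c1` has not been measured. It differs from compound 1 in one place: 2,5-dimethoxyphenyl in place of 3,5-dichlorophenyl on a saturated ring carbon. For the measured compounds named here, no step of this kind stands among the measured pairs, so there is nothing to scale it from. The expected step of a number 8.7 percentage points lower from compound 1 to compound 3 (within the scatter) is small and downward, with a fair chance of no change beyond the scatter. Compound 3 is expected to give 44% in this assay, within 24% to 64%.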

Compound 3, a percentage reported as inhibition, at one concentration (the size of the read-out at that concentration, not a potency): 37.2%
Compound 3: middle estimate off by 6.8 percentage points, on the high side; the range from low to high includes it.
By their numbers in this assay, from the lowest: compounds 3, 2 and 1 (each within the scatter of the next, the first and the last beyond it).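

For the compounds shown here, on the saturated ring carbon of the shared core, the aryl group can shift the read-out in this assay: 2,5-dimethoxyphenyl in place of 3,5-dichlorophenyl gives a number 15.5 percentage points lower from compound 1 to compound 3 (beyond the scatter) and is the first step at this position. This single pair covers one exchange only and does not separate the loss of the chlorines from the entry of the methoxy groups. Nothing at hand accounts for the step.

On these data alone, whether an unsubstituted phenyl or a pyridine ring on this carbon would read closer to compound 1 or compound 3 stays open. So does the effect of replacing the acetyl group with a longer acyl chain.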